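Replacing a Dimethoxyphenyl Group with Quinolinyl in Calpain Inhibitors

A few compounds are considered here, and "the series" means these few. Any claim that something is new, unique, unknown or untested is made for them only; others in the source may bear on it.

Measured so far in an assay on isolated protein for inhibition of Calpain-1 catalytic subunit (Homo sapiens); a lower number here means a stronger inhibitor, a higher number a weaker inhibitor:
Compound 1 `CCC(NC(=O)C(CC(C)C)NC(=O)OCc1ccccc1)C(=O)C(=O)NCCCCCO` gives 500 nM.
Compound 2 `CCC(NC(=O)C(CC(C)C)NC(=O)OCc1ccccc1)C(=O)C(=O)NCC1(C)CC(O)CC(C)(C)C1` gives 420 nM.
Compound 3 `CCC(NC(=O)C(CC(C)C)NC(=O)OCc1ccccc1)C(=O)C(=O)NCc1cc(OC)cc(OC)c1` gives 2300 nM.

Compound 3 has the highest number of the three, so it is the weakest inhibitor of this set. Compound 4 `CCC(NC(=O)C(CC(C)C)NC(=O)OCc1ccccc1)C(=O)C(=O)NCc1ccc2ccccc2n1` differs from it by one change: quinolin-2-yl in place of 3,5-dimethoxyphenyl on a saturated chain carbon bound to an amide-type nitrogen. For the measured compounds named here, the steps that bear on this position are a 4.6-fold higher number from compound 1 to compound 3 (0.66 log units; beyond the scatter) and a 5.5-fold higher number from compound 2 to compound 3 (0.74 log units; beyond the scatter), both modest and both showing that the 3,5-dimethoxyphenyl group weakened binding relative to non-aromatic groups. Going by the values given here, no measured step compares two aromatic groups, so the effect of quinolin-2-yl is untested. The expectation is a step of a 1.3-fold lower number from compound 3 to compound 4 (0.11 log units; within the scatter), that is, roughly no change beyond the scatter. Compound 4 is therefore estimated at 1800 nM, with a range from 600 nM to 5500 nM.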

Compound 4, inhibition constant: 130 nM
Beside the measured number, compound 4's estimate is 14-fold (1.14 log units) above it, and the stated range ends above it.
By their numbers in this assay, from the lowest: compound 4; then compounds 2 and 1 (each within the scatter of the next); then compound 3.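

In this assay, the change to quinolin-2-yl gives an 18-fold lower number from compound 3 to compound 4 (1.25 log units; beyond the scatter), so this position separates one aromatic group sharply from another. Compound 4 also improves on the non-aromatic groups, with a 3.2-fold lower number from compound 2 to compound 4 (0.51 log units; beyond the scatter) and a 3.8-fold lower number from compound 1 to compound 4 (0.59 log units; beyond the scatter), so the loss seen with compound 3 does not apply to every aromatic group here. No supporting measurement bears on the reason for this gain. The swap removes both methoxy groups and adds a ring nitrogen and a second ring, and these effects cannot be separated. Going by these compounds, what naphthalen-2-yl or plain phenyl would give here remains open.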